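A few compounds are considered here, and "the series" means these few. Any claim that something is new, unique, unknown or untested is made for them only; others in the source may bear on it.

In an ADME assay on microsomes from liver (Homo sapiens) for metabolic stability, read by LC-MS, using NADPH, with a stated time of 10 min, tested at 0.5 uM (a lower number here means that less of the compound is left, a higher number that more of the compound is left), the measured compounds are:

compound 1 `CC(=O)Nc1cc(-c2ccc(OC[C@@H](N)CC(C)C)c(C)c2)ccn1`: 91%
compound 2 `CC(=O)Nc1cc(-c2ccc(OC[C@@H](N)CC(C)C)c(Cl)c2)ccn1`: 89%

Compound 2 gives 89% and compound 1 gives 91%, so the two values lie within the usual scatter of each other. In both cases, most of the compound is still present when the measurement is taken.

The next compound, compound 3 `CC(=O)Nc1cc(-c2ccc(OC[C@@H](N)CC(C)C)c(OC(F)(F)F)c2)ccn1`, has trifluoromethoxy in place of chloro on an aromatic carbon, ortho to a (2-amino-4-methylpentyl)oxy group: trifluoromethoxy in place of chloro on an aromatic carbon.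

For the measured compounds named here, only one measured step bears on this change, and it involves the same aromatic carbon: a number 2 percentage points lower from compound 1 to compound 2 (within the scatter). That step swaps chloro for methyl and stays within the scatter. It therefore gives no reason to expect a real shift in this assay, although no compound with trifluoromethoxy has been measured yet. The expected change is a number 3 percentage points lower from compound 2 to compound 3 (within the scatter), which is a small estimated step with no firm direction. With so little evidence, the range is kept wide and extends further toward lower numbers.

In this assay, compound 3 is estimated at 86%, with an expected range of 70% to 97%.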

Compound 3, percent of the compound remaining: 91%
Estimate against measurement, compound 3: 5 percentage points below; the measured number falls inside the stated range.
By their numbers in this assay, from the lowest: compounds 2, 1 and 3 (each within the scatter of the next).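

In this assay, replacing chloro with trifluoromethoxy, a group with more heavy atoms that also brings in oxygen and fluorine, gives a number 2 percentage points higher from compound 2 to compound 3 (within the scatter). Replacing methyl with the same group gives no change at the digits printed from compound 1 to compound 3 (within the scatter), so methyl, chloro and trifluoromethoxy all lie within the scatter of one another on this aromatic carbon, ortho to a (2-amino-4-methylpentyl)oxy group, whereas the earlier pair covered only methyl and chloro. Nothing measured here explains why a group of this size leaves the read-out within the scatter.

These three compounds show only that this substituent can vary across these three groups without a readable shift, and they say nothing about how a carboxylic acid, an amine or a longer chain on the same carbon would behave. Going by these compounds, all three numbers also sit close together near the top of the scale after a short incubation, so any real differences in stability between these compounds remain open, as does the effect of changes elsewhere on the shared core.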